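A few compounds are considered here, and "the series" means these few. Any claim that something is new, unique, unknown or untested is made for them only; others in the source may bear on it.

Two relatives of the test compound have been examined in a functional assay on HepG2 cells (Homo sapiens) for cytotoxicity, read by MTT assay, with a stated time of 48 h; a lower number here means a stronger inhibitor, a higher number a weaker inhibitor. Compound 1 `CC1=NN(C(=O)CN2CCN(C)CC2)C(c2ccccc2O)C1` is recorded as "not active" (no number reported), so it has no number to compare. Among the measured compounds shown here, compound 2 `CC(=O)Oc1ccccc1C1CC(C)=NN1C(=O)CN(C(C)C)C(C)C` gives 34100 nM, the only number available, and so there is no ranking or series trend to draw on.

Compound 3 `CC(=O)Oc1ccccc1C1CC(C)=NN1C(=O)CN1CCC(O)CC1` keeps the core of compound 2 and changes only the amine part. 4-hydroxypiperidin-1-yl in place of diisopropylamino on a saturated chain carbon bound to a carbonyl carbon In words, 4-hydroxypiperidin-1-yl stands in place of diisopropylamino on a saturated chain carbon bound to a carbonyl carbon. The count of heavy atoms stays the same, but the new group brings a ring and a hydroxy group.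

For the measured compounds named here, no measured pair shows what a swap of this kind does in this assay, so the forecast has to start from compound 2 at 34100 nM. The expected change, a 1.3-fold higher number from compound 2 to compound 3 (0.12 log units; within the scatter), is small, perhaps no larger than the usual scatter, and leans towards weaker inhibition. For compound 3 the estimated value is 45000 nM, with an expected range from 15000 nM to 120000 nM.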

Compound 3, half-maximal inhibitory concentration: 12300 nM
Beside the measured number, compound 3's estimate is 3.7-fold (0.56 log units) above it, outside the stated range (below it).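

Among the compounds shown here, the amine part is the first place where a single change can be read in this assay: replacing diisopropylamino with 4-hydroxypiperidin-1-yl on a saturated chain carbon bound to a carbonyl carbon gives a 2.8-fold lower number from compound 2 to compound 3 (0.44 log units; beyond the scatter) and so moves towards stronger inhibition. This modest step lies beyond the usual scatter, which shows that the number responds to a change at this position even while the rest of the molecule stays the same. The count of heavy atoms is also unchanged, so the step comes with a swap in the kind of atoms and their arrangement rather than with a larger group, and no measurement at hand accounts for it.

The ring and the hydroxy group enter together, so these compounds cannot separate them; plain piperidin-1-yl, which has the ring without the hydroxy group, would be the natural group to set beside compound 3. Compound 1 gives "not active" (no number reported) and differs from compound 3 in more than one place, which leaves open what its methylpiperazine ring and free phenol hydroxy group each do.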